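The source may hold more compounds than are shown below. What is called first, only, known or untested is meant among the compounds shown, and "the series" means these compounds.

Measured so far in a functional assay on PC-3 cells (Homo sapiens) for antiproliferative activity, read by MTT assay, with a stated time of 72 h; on this read-out lower numbers stand for stronger inhibition and higher numbers for weaker inhibition:
compound 1 `CC(C)=CC(=O)Nc1cc2c(N3CCc4ccccc43)ncnc2cc1O[C@@H]1CCOC1` gives 4620 nM
compound 2 `CC(C)/C=C/C(=O)Nc1cc2c(N3CCc4ccccc43)ncnc2cc1O[C@@H]1CCOC1` gives 11200 nM

Compound 2 stands highest of the two numbers; the step from compound 1 to compound 2 reads a 2.4-fold higher number from compound 1 to compound 2 (0.38 log units; beyond the scatter). Compound 3 `CCN(CC)C/C=C/C(=O)Nc1cc2c(N3CCc4ccccc43)ncnc2cc1O[C@@H]1CCOC1` differs from compound 2 by (diethylamino)methyl in place of isopropyl on a double-bonded chain carbon bound to a double-bonded chain carbon. Among the measured compounds shown here, no measured step covers this change; the step from compound 1 to compound 2 touches the same chain and shows that this position moves the number beyond the scatter. For compound 3 a modest step in this assay is therefore expected, with the direction uncertain, stated as a 2.2-fold lower number from compound 2 to compound 3 (0.35 log units; beyond the scatter). Compound 3 is estimated at 5000 nM, within 1500 nM to 15000 nM.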

Compound 3, half-maximal inhibitory concentration: 5780 nM
Compound 3: the middle estimate sits 1.2-fold (0.06 log units) below what was measured; the measured number falls inside the stated range.
By their numbers in this assay, from the lowest: compounds 1, 3 and 2 (each within the scatter of the next, the first and the last beyond it).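

In this assay, (diethylamino)methyl in place of isopropyl gives a 1.9-fold lower number from compound 2 to compound 3 (0.29 log units; within the scatter) and 3-(diethylamino)prop-1-en-1-yl in place of 2-methylprop-1-en-1-yl on a carbonyl carbon gives a 1.3-fold higher number from compound 1 to compound 3 (0.10 log units; within the scatter) as the second reading. The chain therefore takes a group with a nitrogen atom, and neither step lies beyond the scatter, which the all-carbon groups of compounds 1 and 2 could not show. Nothing available explains these steps. Going by these compounds, whether a dimethylamino, piperidine or morpholine group at this place, or a longer chain carrying the diethylamino group, would move the number remains open.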